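Methyl for hydrogen on a benzylic carbon: two ureas compared

The compounds below may be only part of what the source reports. "The series", "measured", "known", "first", "only" and "open" are said of these compounds alone.

Four compounds are considered here, all measured or to be measured in a functional assay on HT-29 cells (Homo sapiens) for cytotoxicity, read by sulforhodamine B assay, with a stated time of 48 h; a lower number here means a stronger inhibitor, a higher number a weaker inhibitor. Compound 1 `Cc1ccccc1NS(=O)(=O)c1ccc(NC(=O)NCCCCl)cc1` gives 64000 nM in this assay. Compound 2 `CCc1ccccc1NS(=O)(=O)c1ccc(NC(=O)NCCCCl)cc1` returns only a limit of the assay, > 200000 nM, and not a number. The change between them, (methyl in place of hydrogen on a saturated chain carbon bound to an aromatic carbon), produced an at least 3.1-fold higher number from compound 1 to compound 2 (0.49 log units; beyond the scatter); the size of that step is bounded by the limit of > 200000 nM in this assay, at which 1 of the 3 values shown sits.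

Compound 3 `CCNC(=O)Nc1ccc(S(=O)(=O)Oc2ccccc2C)cc1` belongs to a different core; the difference between the two cores is not broken down here. In this assay compound 3 gives 12000 nM, a lower number than compound 1 shows and beyond the usual scatter of such measurements.

Compound 4 `CCNC(=O)Nc1ccc(S(=O)(=O)Oc2ccccc2CC)cc1` has not yet been measured. It differs from compound 3 by methyl in place of hydrogen on a saturated chain carbon bound to an aromatic carbon, the same change, at the same place on a saturated chain carbon bound to an aromatic carbon, that separates compound 1 from compound 2. Given that the change once gave an at least 3.1-fold higher number from compound 1 to compound 2 (0.49 log units; beyond the scatter), a weakening of a comparable size is expected from compound 3 to compound 4 in this assay, namely a 3.3-fold higher number from compound 3 to compound 4 (0.52 log units; beyond the scatter). On that basis compound 4 is estimated to give about 40000 nM in this assay, with a plausible range from 15000 nM to 150000 nM, and some chance that only a limit is reported.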

Compound 4, half-maximal inhibitory concentration: 12000 nM
Compound 4: middle estimate off by 3.3-fold (0.52 log units), on the high side; the whole stated range lies above it.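

In this assay, methyl in place of hydrogen on a saturated chain carbon bound to an aromatic carbon gives no change at the digits printed from compound 3 to compound 4 (within the scatter), so the weakening seen on the core of compound 1 did not carry over to the core of compound 3, and the two steps do not agree: the same change on two cores in this assay, an at least 3.1-fold higher number (0.49 log units; beyond the scatter) from compound 1 to compound 2 and no change at the digits printed (within the scatter) from compound 3 to compound 4, at least 3.1-fold (0.49 log units) apart, beyond the scatter of two such steps

Compound 2 gives > 200000 nM, which is a limit of the assay and not a number, so the earlier step has a bound and not a measured size: the limit of > 200000 nM in this assay, at which 1 of the 4 values shown sits.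

The comparison shows that, for these two pairs, the effect of this change cannot be assumed to transfer from one core to the other, but it does not show which part of the difference between the cores accounts for this, and with a single pair on each core it gives no rule for any other core.

The compounds shown leave open how a propyl group or a longer chain at the same place would read on either core, and whether the step from methyl to ethyl would again differ between them. They also leave open whether an amine or a carboxylic acid carried on that chain would separate the two cores in the same way.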